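Chloro for Trifluoromethoxy: Expected Shift in Mitochondrial Activation

The compounds below may be only part of what the source reports. "The series", "measured", "known", "first", "only" and "open" are said of these compounds alone.

Measured so far:
compound 1, `Oc1nc2nonc2nc1Nc1ccccc1C(F)(F)F`, gives 10600 nM
compound 2, `Oc1nc2nonc2nc1Nc1ccccc1OC(F)(F)F`, gives 7100 nM

Both numbers come from an assay on mitochondria from L6 cells (Rattus norvegicus) for activation, with a stated time of 90 min; a higher number here means that more compound is needed for the effect, a lower number that less compound is needed. Compound 2 holds the lower of the two numbers, but the step of a 1.5-fold lower number from compound 1 to compound 2 (0.17 log units; within the scatter) lies within the scatter, so the two compounds cannot be told apart on this evidence. Compound 3, `Oc1nc2nonc2nc1Nc1ccccc1Cl`, has not been measured. It differs from compound 2 in one place: chloro in place of trifluoromethoxy on an aromatic carbon. For the measured compounds named here, only one measured step bears on this change, a 1.5-fold lower number from compound 1 to compound 2 (0.17 log units; within the scatter), which swapped one fluorine-bearing group for another at the same place and moved the number no further than the scatter. Going by the values given here, no measured pair carries chloro at that place, so there is no direct guide. Compound 3 is therefore expected to sit close to compound 2, with a step of a 1.1-fold higher number from compound 2 to compound 3 (0.05 log units; within the scatter) that is not expected to exceed the scatter. The estimate for compound 3 is 8000 nM, with a range from 3000 nM to 20000 nM.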

Compound 3, half-maximal effective concentration: 6300 nM
Beside the measured number, compound 3's estimate is 1.3-fold (0.10 log units) above it, and the stated range covers the measured number.
By their numbers in this assay, from the lowest: compounds 3, 2 and 1 (each within the scatter of the next).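

In this assay, chloro, with 1 heavy atom, stands in for trifluoromethoxy, with 5 heavy atoms, and the result is a 1.1-fold lower number from compound 2 to compound 3 (0.05 log units; within the scatter). Chloro in place of trifluoromethyl gives a 1.7-fold lower number from compound 1 to compound 3 (0.23 log units; within the scatter) and also stays within the scatter, so the three compounds cannot be told apart. For the compounds shown here, the earlier pair compared only two fluorine-bearing groups, whereas this result shows that a single chlorine at this place on an aromatic carbon also gives a number indistinguishable from theirs, and nothing available here explains why.

From the compounds shown here alone, whether an amine, a carboxylic acid or a longer chain at this place would move the number beyond the scatter remains open. So does the result with a plain hydrogen there, which would show how much any group at this place contributes.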